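Swapping a Dichlorophenyl Sulfonyl for a Methoxyphenyl Sulfonyl

A few compounds are considered here, and "the series" means these few. Any claim that something is new, unique, unknown or untested is made for them only; others in the source may bear on it.

Three measured compounds share one core and differ only in the group on a ring nitrogen at one end. Compound 1 `COC(=O)c1ccc(C2SCC(=O)N2c2ccc(N3CCN(Cc4cccc([N+](=O)[O-])c4)CC3)cn2)c(OC)c1` carries a 3-nitrobenzyl group there. In a functional assay on NALM-6 cells (Homo sapiens) for antiproliferative activity, read by MTT assay and trypan blue exclusion, with a stated time of 72 h (a higher number here means a weaker inhibitor, a lower number a stronger inhibitor), compound 1 gives > 100000 nM, which is a limit of the assay and not a number (the limit of > 100000 nM in this assay, at which 1 of the 3 values shown sits). Compound 2 `COC(=O)c1ccc(C2SCC(=O)N2c2ccc(N3CCN(S(=O)(=O)c4ccccc4)CC3)cn2)c(OC)c1` carries a phenylsulfonyl group and gives 48400 nM in this assay. Compound 3 `COC(=O)c1ccc(C2SCC(=O)N2c2ccc(N3CCN(S(=O)(=O)c4cc(Cl)ccc4Cl)CC3)cn2)c(OC)c1` carries a (2,5-dichlorophenyl)sulfonyl group and gives 27400 nM in this assay. Compound 3 thus holds the lowest of the two numbers, but its gap to compound 2, a 1.8-fold lower number from compound 2 to compound 3 (0.25 log units; within the scatter), stays within the scatter, so the two cannot be ranked. Both sulfonyl compounds sit beyond the scatter from the limit: an at least 2.0-fold lower number from compound 1 to compound 2 (0.31 log units; beyond the scatter) and an at least 3.6-fold lower number from compound 1 to compound 3 (0.56 log units; beyond the scatter).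

Compound 4 `COC(=O)c1ccc(C2SCC(=O)N2c2ccc(N3CCN(S(=O)(=O)c4ccc(OC)cc4)CC3)cn2)c(OC)c1` is not yet measured. It differs from compound 3 in one place: 4-methoxyphenyl in place of 2,5-dichlorophenyl on a sulfonyl sulfur. Within the data shown here, only the step from compound 2 to compound 3 bears on this change, since it too swapped one aromatic ring on the sulfonyl sulfur for another, and that step stayed within the scatter. Compound 4 is therefore expected to land near compound 3. In this assay a step of a 1.5-fold higher number from compound 3 to compound 4 (0.16 log units; within the scatter) is expected. The estimate for compound 4 is 40000 nM, expected to lie between 15000 nM and 100000 nM.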

Compound 4, half-maximal inhibitory concentration: 29400 nM
Estimate against measurement, compound 4: 1.4-fold (0.13 log units) above; the range from low to high includes it.
By their numbers in this assay, from the lowest: compounds 3, 4 and 2 (each within the scatter of the next). At a limit, above all of these: compound 1.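

The change from 2,5-dichlorophenyl to 4-methoxyphenyl replaces chlorine with an oxygen that counts as a hydrogen-bond acceptor, yet in this assay it gives a 1.1-fold higher number from compound 3 to compound 4 (0.03 log units; within the scatter). Adding methoxy to the plain phenyl ring gives a similar outcome, a 1.6-fold lower number from compound 2 to compound 4 (0.22 log units; within the scatter), so compounds 2, 3 and 4 cannot be ranked, and none of these rings on the sulfonyl sulfur separates itself from the others. Compound 4 is also the third sulfonyl compound to stand clear of compound 1, with an at least 3.4-fold lower number from compound 1 to compound 4 (0.53 log units; beyond the scatter), although that step only has a lower bound, as the value for compound 1 is a limit of the assay and not a number: the limit of > 100000 nM in this assay, at which 1 of the 4 values shown sits.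

On these data alone, what stays open is whether the gain over compound 1 belongs to the sulfonyl link, to the loss of the 3-nitrobenzyl group, or to both, and a methylsulfonyl group or a plain benzyl group would help to separate these. As far as these compounds go, it is also open whether a ring on the sulfonyl sulfur bearing an amine or a carboxylic acid would move the number beyond the scatter, which the chloro and methoxy rings did not do.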